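Amide to methyl ester on the shared core

The source may report more compounds than this note shows. Statements on the series, on what has been measured and on what is new or still open speak of the compounds shown alone.

Compound 1 `NC(=O)[C@H]1C[C@@H](c2coc3ccccc3c2=O)N(c2ccccc2)O1` is tested in a functional assay on PC-3 cells (Homo sapiens) for inhibition, read by sulforhodamine B assay, with a stated time of 48 h; on this read-out higher numbers stand for weaker inhibition and lower numbers for stronger inhibition. In this assay compound 1 reaches only the limit > 60000 nM, so no number is known for it. Compound 2 `O=C1[C@H]2[C@H](ON(c3ccccc3)[C@@H]2c2coc3ccc(F)cc3c2=O)C(=O)N1c1ccccc1` likewise reaches only the limit > 60000 nM in this assay. Everything shown so far sits at the limit of > 60000 nM in this assay, at which 2 of the 2 values shown sit. Compound 3 `COC(=O)[C@H]1C[C@@H](c2coc3ccccc3c2=O)N(c2ccccc2)O1` differs from compound 1 by methoxy in place of amino on a carbonyl carbon, read one bond further out as carbamoyl to methoxycarbonyl. Among the measured compounds shown here, no measured step between two compounds exists here. The expected step is none beyond the scatter: a step that the limit leaves unreadable from compound 1 to compound 3. Compound 3 is estimated at 70000 nM, between 20000 nM and 250000 nM, most likely again reported only as a limit.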

Compound 3, half-maximal inhibitory concentration: > 60000 nM
Compound 3: no number, only a limit (the forecaster's own chance of this, stated with the estimate: 75%); the middle value lies beyond the limit too.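

The step between compound 1 and compound 3 cannot be read, because both stand only as limits in this assay: the limit of > 60000 nM in this assay, at which 3 of the 3 values shown sit. The compounds shown leave open whether any change on the shared core yields a readable value.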